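This account rests on a few compounds, and the source may have more. Where it says the series, first, only, none or still open, it means among the compounds named here.

Measured in an ADME assay on MT4 cells (Homo sapiens) for cytotoxicity, read by MTT assay, with a stated time of 4 days; a higher number here means that more compound is tolerated, a lower number that less compound is tolerated:
- compound 1 `Cc1c(Cc2c(F)cccc2F)nc(N(C)C(C)C)[nH]c1=O`: 79000 nM
- compound 2 `Cc1c(Cc2c(F)cccc2F)nc(N(C)C2CCCCC2)[nH]c1=O`: > 72000 nM, a limit
- compound 3 `CCCN(CCC)c1nc(Cc2c(F)cccc2F)c(C)c(=O)[nH]1`: > 74000 nM, a limit

Compound 3 has no number in this assay: its > 74000 nM is a limit. Compound 2 is also known only by a limit, > 72000 nM. Going by the values given here, compound 1, at 79000 nM, holds the only number.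

Compound 4 `Cc1c(Cc2c(F)cccc2F)nc(N2CCCCC2C)[nH]c1=O` has not yet been measured. It differs from compound 3 by one change, 2-methylpiperidin-1-yl in place of dipropylamino on an aromatic carbon.

The measured steps that alter this amino substituent are a step that the limit leaves unreadable from compound 1 to compound 2, a step that the limit leaves unreadable from compound 1 to compound 3 and a step that the two limits leave unreadable from compound 2 to compound 3. None of them has a readable size, so none provides a size to carry over. They do show that all three substituents leave the compounds tolerated to high concentrations, with compound 1 at 79000 nM as the one firm anchor.

No step beyond the scatter is therefore expected in this assay, in either direction, and a further limit is as likely as a number. The expected change is an at least 1.0-fold lower number from compound 3 to compound 4 (0.02 log units; that floor lies within the scatter). For compound 4 the estimated value is 70000 nM, with an expected range from 30000 nM to 100000 nM.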

Compound 4, half-maximal cytotoxic concentration: 75000 nM
For compound 4 the middle estimate is 1.1-fold (0.03 log units) below the measured one; measured number inside the range.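

In this assay, going by these compounds alone, replacing isopropyl(methyl)amino with 2-methylpiperidin-1-yl is a 1.1-fold lower number from compound 1 to compound 4 (0.02 log units; within the scatter), the first step of readable size at this position. A six-membered non-aromatic ring with 1 hetero atom on the aromatic carbon between two ring nitrogen atoms therefore gives a number indistinguishable from that of the open isopropyl(methyl)amino group, so closing the substituent into a ring shows no measurable effect on tolerance in this pair. The steps from compound 2 and from compound 3 to compound 4 cannot be read: both of those compounds carry only limits, so the comparison with dipropylamino and with cyclohexyl(methyl)amino stays without a size.

Every compound shown keeps the same shared core and carries only carbon groups on this amino nitrogen, so whether any substituent here can move the number beyond the scatter remains open. As far as these compounds go, what a morpholin-4-yl group, a free amine or a longer chain ending in a carboxylic acid would do on this aromatic carbon in this assay is also open.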